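Opening a Bicyclic Amine into a Simple Aminopyrrolidine

The source may hold more compounds than are shown below. What is called first, only, known or untested is meant among the compounds shown, and "the series" means these compounds.

Compound 1 `O=C(CCc1ccc(C(F)(F)F)cc1)Nc1ccc2nc(N3CC4CC3CN4)ccc2c1` is the starting point of this comparison. In an assay on isolated protein for displacement of a labelled ligand from melanin-concentrating hormone receptor 1 (Homo sapiens) (a higher number here means a weaker inhibitor, a lower number a stronger inhibitor), compound 1 gives 210 nM, the highest of the two numbers in hand, and so the weaker of the two measured compounds. Its neighbour, compound 2 `CC(=O)NC1CCN(c2ccc3cc(NC(=O)CCc4ccc(C(F)(F)F)cc4)ccc3n2)C1`, gives 5 nM in this assay, a step of a 42-fold lower number from compound 1 to compound 2 (1.62 log units; beyond the scatter).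

Compound 3 `NC1CCN(c2ccc3cc(NC(=O)CCc4ccc(C(F)(F)F)cc4)ccc3n2)C1` has not been measured yet. It differs from compound 1 in one place: a group of 6 heavy atoms (4 carbon, 2 nitrogen; one five-membered non-aromatic ring with 1 hetero atom) in place of a group of 7 heavy atoms (5 carbon, 2 nitrogen; 2 five-membered non-aromatic rings with 1 hetero atom each), on an aromatic carbon. The change from compound 1 to compound 2 bears directly on this, since there too the bicyclic group on that aromatic carbon gave way to a single five-membered ring carrying a nitrogen substituent, and the number fell sharply. Compound 3 carries the bare 3-aminopyrrolidin-1-yl group rather than the acetylated version found in compound 2, so the gain may be somewhat smaller, but a large drop is still expected in this assay.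

Compound 3 is therefore estimated at 20 nM in this assay, with a range from 5 nM to 80 nM, a step of an 11-fold lower number from compound 1 to compound 3 (1.02 log units; beyond the scatter).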

Compound 3, half-maximal inhibitory concentration: 12 nM
Beside the measured number, compound 3's estimate is 1.7-fold (0.22 log units) above it, and the stated range covers the measured number.
By their numbers in this assay, from the lowest: compound 2; then compound 3; then compound 1.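

In this assay, the single ring of 3-aminopyrrolidin-1-yl on its own gives an 18-fold lower number from compound 1 to compound 3 (1.24 log units; beyond the scatter) in place of the group with two five-membered rings, so the large gain seen with compound 2 does not depend on the acetyl group. Hydrogen in place of acetyl on the amine nitrogen gives a 2.4-fold higher number from compound 2 to compound 3 (0.38 log units; beyond the scatter), a modest step beside the large one, which shows that most of the gain in these three compounds comes with the change of ring and a smaller part with the acetyl group. Nothing in the data shown explains why either change moves the number as it does.

Going by these compounds, only hydrogen and acetyl have been compared on that nitrogen, so it remains open whether a longer acyl chain, a benzoyl group or a methanesulfonyl group would lower the number further or raise it. On these data alone, it is also open whether the gain depends on the five-membered ring, which a piperidine carrying the same amine on the shared core would test.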